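The source may hold more compounds than are shown below. What is called first, only, known or untested is meant among the compounds shown, and "the series" means these compounds.

Measured so far:
- compound 1, `CC(=O)Oc1ccc(-c2ccc(F)cc2F)cc1C(=O)O`, gives 13.7% in a functional assay on the whole organism (Ear) for inhibition, with Mus musculus as the target, at a dose of 40 mg/kg by the oral route; on this read-out higher numbers stand for more inhibition at the one dose given (going by the name of the read-out) and lower numbers for less inhibition
- compound 2, `CC(=O)Oc1ccc(-c2ccc(F)cc2F)cc1C(=O)NCc1ccccc1`, gives 34.1% in this assay

Of these two numbers, compound 2 holds the higher one, and the gap to compound 1 lies beyond the usual scatter of this kind of measurement. Among the compounds with values here, the only step measured so far is a number 20.4 percentage points higher from compound 1 to compound 2 (beyond the scatter), a change at the carbonyl carbon where benzylamino replaced hydroxy.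

Compound 3, `CC(=O)Oc1ccc(-c2ccc(F)cc2F)cc1C(=O)NN1CCOCC1`, is not yet measured. It differs from compound 2 in one place: morpholin-4-yl in place of benzyl on an amide-type nitrogen. The amide itself stays; only the group on its nitrogen changes.

Within the data shown here, no measured step tests a swap of one amide substituent for another, so the step from compound 1 to compound 2 bears on it only loosely, in that it shows the amide rather than the acid carries the higher number. A change of the size seen between compound 1 and compound 2 is therefore not expected here; a smaller shift, if any, is more likely, and its direction cannot be read from the two numbers in hand. For compound 3, the expected step in this assay is a number 8.1 percentage points lower from compound 2 to compound 3 (within the scatter), a shift that may well sit within the scatter. Compound 3 is thus estimated at 26%, with a plausible range from 8% to 44%.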

Compound 3, a percentage reported as inhibition, in the whole organism at one dose (the size of the read-out at that dose, not a potency): 0%
Compound 3: the middle estimate sits 26 percentage points above what was measured; the measured number lies below the stated range.
By their numbers in this assay, from the lowest: compound 3; then compound 1; then compound 2.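

In this assay, the group on the amide-type nitrogen proves to matter a great deal: morpholin-4-yl in place of benzyl gives a number 34.1 percentage points lower from compound 2 to compound 3 (beyond the scatter), a large step from a change at a single place. Having an amide at the carbonyl carbon therefore does not by itself carry the higher number seen earlier. Replacing hydroxy with (morpholin-4-yl)amino on that carbonyl carbon gives a number 13.7 percentage points lower from compound 1 to compound 3 (beyond the scatter), so the amide can fall below the carboxylic acid as well as rise above it, depending on what its nitrogen bears.

The compounds shown leave open whether the loss follows from removing the benzyl group's aromatic carbon ring or from bringing in the morpholine ring, which carries both a nitrogen and an oxygen. A piperidin-1-yl group on the same nitrogen, or a phenylethyl group with a longer chain to its benzene ring, would separate these readings, and neither is among the compounds here. No measurement is available that accounts for the size or direction of these steps.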